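Lengthening a Side Chain by One Carbon: Two Cases

The compounds below may be only part of what the source reports. "The series", "measured", "known", "first", "only" and "open" are said of these compounds alone.

Compound 1 `CCCCCCc1ccc(-c2c(C)[nH]c(=O)n2C)cc1` and compound 2 `CCCCCCCc1ccc(-c2c(C)[nH]c(=O)n2C)cc1` share a core and differ only by methyl in place of hydrogen on a saturated chain carbon, six bonds along the chain from an aromatic carbon. In a functional assay on the whole organism with Rattus norvegicus as the target (a lower number here means that less compound is needed, a higher number that more compound is needed for the effect), compound 1 needs 0.3 mg/kg, whereas compound 2 needs 30 mg/kg, so the step of a 100-fold higher number from compound 1 to compound 2 (2.00 log units; beyond the scatter) is large. Compound 3 `CCCCCCCCCCOc1ccc(-c2c(C)[nH]c(=O)n2C)cc1` carries a different side chain; how its core differs from that of compound 1 is not broken down here. In this assay compound 3 needs 0.1 mg/kg, the lowest of the three. Compound 4 `CCCCCCCCCCCOc1ccc(-c2c(C)[nH]c(=O)n2C)cc1` is not yet measured and differs from compound 3 by methyl in place of hydrogen on a saturated chain carbon, ten or more bonds along the chain from an oxygen on an aromatic ring. This is the same kind of change as before, though the two side chains are not the same. Because the earlier step of a 100-fold higher number from compound 1 to compound 2 (2.00 log units; beyond the scatter) was so large, a higher number is expected for compound 4. For compound 4 a smaller step is expected, estimated as a 10-fold higher number from compound 3 to compound 4 (1.00 log units; beyond the scatter), since a single example on a different core is a thin basis. Compound 4 is therefore estimated at 1 mg/kg, within a range from 0.1 mg/kg to 30 mg/kg.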

Compound 4, minimum effective dose: 0.1 mg/kg
Compound 4: the middle estimate sits 10-fold (1.00 log units) above what was measured; low and high end bracket the measured number.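

In this assay the new step reads no change at the digits printed from compound 3 to compound 4 (within the scatter), so the large jump seen on the first pair did not carry over to this pair. The two steps clearly differ: the same change on two cores in this assay, a 100-fold higher number (2.00 log units; beyond the scatter) from compound 1 to compound 2 and no change at the digits printed (within the scatter) from compound 3 to compound 4, 100-fold (2.00 log units) apart, beyond the scatter of two such steps. This shows that, among these four compounds, the size of the step on one core does not predict its size on the other, but it does not show what sets the two cases apart, as each step is a single example and the side chains differ in more than one place.

Still open, from the compounds shown here alone, is whether a longer chain on the oxygen would leave the number unchanged. Also open, going by these compounds, is how a chain ending in an amine or a carboxylic acid would behave in this assay.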